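Pyrazine series: aryl ethoxy-to-chloro swap at compound 4

A few compounds are considered here, and "the series" means these few. Any claim that something is new, unique, unknown or untested is made for them only; others in the source may bear on it.

Measured so far:
compound 1 `CCc1nc(-c2cnc(OC)nc2OC)c(CC)nc1NC(CC)CC` — 17.2 nM
compound 2 `CCOc1ccc(-c2nc(OC)c(NC(CC)CC)nc2C)c(Cl)c1` — 5.9 nM
compound 3 `CCc1nc(-c2ccc(Cl)cc2Cl)c(CC)nc1NC(C)CN(C)C` — 489 nM

In an assay on IMR-32 cells for displacement of a labelled ligand from corticotropin-releasing factor receptor 1 (Homo sapiens), read by scintillation counting, with a stated time of 2 h (on this read-out lower numbers stand for stronger inhibition and higher numbers for weaker inhibition), compound 2 gives 5.9 nM, the lowest number of the three. Compound 1 is the nearest of the other two and compound 3 the furthest; both gaps lie beyond the usual scatter, so compound 2 stands as the strongest binder of the set so far.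

Compound 4 `CCC(CC)Nc1nc(C)c(-c2ccc(Cl)cc2Cl)nc1OC` keeps the core and amine of compound 2 and differs on the aryl ring only: chloro in place of ethoxy on an aromatic carbon.

Among the compounds with values here, no step of this kind has been measured. Compound 3 also carries two chloro groups on the aryl ring but with a different amine and core, so its value of 489 nM cannot be read across directly. The step from compound 2 to compound 4 is expected to be a 1.7-fold higher number from compound 2 to compound 4 (0.23 log units; within the scatter), a small change that may not exceed the scatter. Compound 4 is therefore estimated at 10 nM, within a range of 3 nM to 35 nM.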

Compound 4, inhibition constant: 4.3 nM
The estimate for compound 4 lay 2.3-fold (0.37 log units) above the measured number, and the stated range covers the measured number.
By their numbers in this assay, from the lowest: compounds 4 and 2 (each within the scatter of the next); then compound 1; then compound 3.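

In this assay the swap on the aryl ring gives a 1.4-fold lower number from compound 2 to compound 4 (0.14 log units; within the scatter) and so leaves compound 2 and compound 4 within the scatter of each other. At this position, para to a large group, ethoxy with its 3 heavy atoms and 1 hydrogen-bond acceptor and chloro with 1 heavy atom and no acceptor cannot be told apart by this read-out. Nothing at hand explains this match.

Open, from the compounds shown here alone, is whether a longer alkoxy chain, an amine or a carboxylic acid at this position would also stay within the scatter of compound 2.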